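Tail Change at the Amide Nitrogen on a Shared Core

The compounds below may be only part of what the source reports. "The series", "measured", "known", "first", "only" and "open" are said of these compounds alone.

Three compounds have been measured in an assay on isolated protein for inhibition of MAP kinase-activated protein kinase 2 (Homo sapiens), read by HTRF, tested at 10 uM; on this read-out lower numbers stand for less inhibition and higher numbers for more inhibition at the one concentration tested (going by the name of the read-out):

Compound 1, `COC[C@@H]1CCCN1C(=O)C1CCCN1c1cc(Nc2cccc(Br)c2)ncn1`, gives 0%.
Compound 2, `Cc1cccc(Oc2ccnc(N3CCC[C@H]3C(=O)NCCCn3ccnc3)n2)c1`, gives 2%.
Compound 3, `CN(C)CC(C)(C)CNC(=O)[C@@H]1CCCN1c1nccc(Nc2ccccc2)n1`, gives 4%.

All three numbers sit at the low end of what this assay can report, so none of these compounds shows meaningful inhibition at the single concentration tested. Compound 2 stands second highest of the three numbers, but its gap to compound 1 and its gap to compound 3 both lie within the usual scatter of repeated measurements, so no real difference between the three can be claimed.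

Compound 4, `Cc1cccc(Oc2ccnc(N3CCC[C@H]3C(=O)NCc3cccnc3)n2)c1`, is not yet measured. It differs from compound 2 in one place: pyridin-3-yl in place of 2-(1H-imidazol-1-yl)ethyl on a saturated chain carbon bound to an amide-type nitrogen. The rest of the molecule, including the shared core and the aryl ether, stays the same.

Among the measured compounds shown here, no pair of measured compounds differs in just one place, so there is no measured step to lean on for this kind of change. Since compound 2 gives 2% and the other two compounds also sit at the bottom of the scale, the expectation in this assay is a step of no size beyond the scatter, in either direction. Compound 4 is therefore estimated to give 3%, in a range from -5% to 12%, which corresponds to an expected step of a number 1 percentage points higher from compound 2 to compound 4 (within the scatter).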

Compound 4, a percentage reported as inhibition, at one concentration (the size of the read-out at that concentration, not a potency): 0%
The estimate for compound 4 lay 3 percentage points above the measured number, and the stated range covers the measured number.
By their numbers in this assay, from the lowest: compounds 1, 4, 2 and 3 (each within the scatter of the next).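

In this assay, among the compounds shown here, this is the first change that can be read at this position: pyridin-3-yl in place of 2-(1H-imidazol-1-yl)ethyl on a saturated chain carbon bound to an amide-type nitrogen gives a number 2 percentage points lower from compound 2 to compound 4 (within the scatter), so the two tails cannot be told apart. The swap replaces a five-membered aromatic ring with 2 hetero atoms by a six-membered aromatic ring with 1 hetero atom, and 2 hydrogen-bond acceptors by 1, yet both compounds stay at the bottom of the scale. The data therefore show that this particular exchange of aromatic tails brings no detectable inhibition at the one concentration tested, and nothing available explains why the two tails read alike.

As far as these compounds go, what remains open is whether a quite different group at this position, such as a carboxylic acid, a morpholine or a simple phenyl ring, would lift the number clear of the scatter. With both tails this close to the floor of the scale, the compounds shown also leave open whether any change at this position can affect inhibition while the rest of the molecule stays the same.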